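The source may hold more compounds than are shown below. What is called first, only, known or untested is meant among the compounds shown, and "the series" means these compounds.

Compound 1 `CC(=O)N1N=C(c2cc(O)c(O)c([N+](=O)[O-])c2)CC1c1nccs1` gives 160 nM in an assay for inhibition of Catechol O-methyltransferase (Rattus norvegicus), read by fluorescence and spectrophotometry; a lower number here means a stronger inhibitor, a higher number a weaker inhibitor.
Compound 2 `CC(=O)N1N=C(c2cc(O)c(O)c([N+](=O)[O-])c2)CC1c1ccc(C#N)cc1` gives 48 nM in this assay.
Compound 3 `CC(=O)N1N=C(c2cc(O)c(O)c([N+](=O)[O-])c2)CC1c1cccc(C#N)c1` gives 79 nM in this assay.

Compound 3 holds the second highest of the three numbers: its nearest neighbour is compound 2, with a 1.6-fold higher number from compound 2 to compound 3 (0.22 log units; within the scatter), and its furthest is compound 1, with a 2.0-fold lower number from compound 1 to compound 3 (0.31 log units; beyond the scatter). Compound 4 `CC(=O)N1N=C(c2cc(O)c(O)c([N+](=O)[O-])c2)CC1c1cccc(O)c1` differs from compound 3 by hydroxy in place of cyano on an aromatic carbon. Going by the values given here, no measured step exchanges a single substituent on the six-membered aromatic ring of carbon only; every recorded step swaps the whole group on the saturated ring carbon, namely a 3.3-fold lower number from compound 1 to compound 2 (0.52 log units; beyond the scatter), a 2.0-fold lower number from compound 1 to compound 3 (0.31 log units; beyond the scatter) and a 1.6-fold higher number from compound 2 to compound 3 (0.22 log units; within the scatter), all of them modest or within the scatter. Compound 4 is therefore expected to stay close to compound 3 in this assay, most likely without a step beyond the scatter. The step expected for compound 4 is a 1.3-fold higher number from compound 3 to compound 4 (0.10 log units; within the scatter). Compound 4 is estimated at 100 nM, between 40 nM and 250 nM.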

Compound 4, half-maximal inhibitory concentration: 75 nM
Beside the measured number, compound 4's estimate is 1.3-fold (0.12 log units) above it; low and high end bracket the measured number.
By their numbers in this assay, from the lowest: compounds 2, 4 and 3 (each within the scatter of the next); then compound 1.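

In this assay, going by these compounds alone, hydroxy in place of cyano on an aromatic carbon, meta to a large group, is the first exchange of a single substituent on this ring, and it gives a 1.1-fold lower number from compound 3 to compound 4 (0.02 log units; within the scatter), so the two groups cannot be told apart here. The 3-hydroxyphenyl group likewise stays within the scatter of the 4-cyanophenyl group, with a 1.6-fold higher number from compound 2 to compound 4 (0.19 log units; within the scatter), and keeps a modest margin over 1,3-thiazol-2-yl, with a 2.1-fold lower number from compound 1 to compound 4 (0.33 log units; beyond the scatter). Nothing available accounts for this result. The compounds shown leave open whether an amine or a carboxylic acid on the same aromatic carbon would also stay within the scatter of compound 3.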